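The source may hold more compounds than are shown below. What is called first, only, known or untested is meant among the compounds shown, and "the series" means these compounds.

Compound 1 `COc1cc(OC)c2c(=O)cc(-c3ccc(OCC(O)CN(C)C)cc3)oc2c1`: 71%
Compound 2 `COc1cc(OC)c2c(=O)cc(-c3ccc(Br)cc3)oc2c1`: 22%

Of the compounds shown here, two of the shared core have been measured in a functional assay (Homo sapiens) for antiproliferative activity, read by resazurin assay, with a stated time of 48 h, tested at 20 uM; a lower number here means a weaker effect, a higher number a stronger effect of the compound at the concentration tested. Within the data shown here, compound 1 gives 71% and compound 2 gives 22%, so compound 2 stands lowest of the two numbers, with compound 1 as its only neighbour well beyond the scatter.

Compound 3 `COc1cc(OC)c2c(=O)cc(-c3ccc(NCCN4CCCC4)cc3)oc2c1` is the next member. The change that turns compound 2 into compound 3 is (2-(pyrrolidin-1-yl)ethyl)amino in place of bromo on an aromatic carbon. Among the measured compounds shown here, the one measured step that bears on this is the one leading into compound 2: a number 49 percentage points lower from compound 1 to compound 2 (beyond the scatter), where an aromatic side chain carrying a basic nitrogen was replaced by a single bromine and inhibition fell sharply. The change to compound 3 runs the other way, replacing that bromine with a chain that again ends in a basic nitrogen, so a large rise in this assay is expected, roughly reversing the earlier loss. The expected step is a number 43 percentage points higher from compound 2 to compound 3 (beyond the scatter). For compound 3 the estimate in this assay is 65%, within a range from 45% to 85%.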

Compound 3, a percentage reported as inhibition, at one concentration (the size of the read-out at that concentration, not a potency): 80%
The estimate for compound 3 lay 15 percentage points below the measured number, and the stated range covers the measured number.
By their numbers in this assay, from the lowest: compound 2; then compounds 1 and 3 (each within the scatter of the next).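

Across this assay, the step of a number 58 percentage points higher from compound 2 to compound 3 (beyond the scatter) shows that the low reading of compound 2 is not fixed by the shared core, since a second, different chain on this aromatic carbon also gives a far larger read-out than bromo does. The step of a number 9 percentage points higher from compound 1 to compound 3 (within the scatter) adds that 3-(dimethylamino)-2-hydroxypropoxy and (2-(pyrrolidin-1-yl)ethyl)amino cannot be told apart here, even though they differ in the atom that joins them to the ring, in the hydroxyl group and in the pyrrolidine ring. Among these compounds, then, the two long amine-bearing chains sit together and well clear of bromo, with none of the three going against that, but nothing available explains why.

Still open, going by these compounds, is whether the amine at the end of the chain matters, which a chain ending in a hydroxyl group or a carboxylic acid in place of the pyrrolidine would test. A longer chain between the two nitrogens, or a morpholine ring in place of the pyrrolidine, would show how much room this position allows, though a read-out at one concentration would not give a potency.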